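The source may hold more compounds than are shown below. What is called first, only, known or untested is meant among the compounds shown, and "the series" means these compounds.

Measured compounds:
- compound 1 `C=CCn1ncc2ccc(N/C(C)=C3\C(=O)C=C(C)OC3=O)cc21`; in an ADME assay on RAW264.7 cells (Mus musculus) for cytotoxicity, read by resazurin assay, with a stated time of 48 h (a lower number here means that less compound is tolerated, a higher number that more compound is tolerated), compound 1 gives > 100000 nM, which is a limit of the assay rather than a number.
- compound 2 `CC1=CC(=O)/C(=C(/C)Nc2ccc3cnn(Cc4ccc(C)cc4)c3c2)C(=O)O1`; in this assay compound 2 gives > 100000 nM, also a limit.
- compound 3 `C=CCn1nc(Cl)c2ccc(N/C(C)=C3\C(=O)C=C(C)OC3=O)cc21`; in this assay compound 3 gives > 100000 nM, again a limit.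

All three measured values sit at the same limit (the limit of > 100000 nM in this assay, at which 3 of the 3 values shown sit), so neither measured step can be read in size. The change 4-methylphenyl in place of vinyl on a saturated chain carbon bound to an aromatic nitrogen gives a step that the two limits leave unreadable from compound 1 to compound 2. The change chloro in place of hydrogen on an aromatic carbon gives a step that the two limits leave unreadable from compound 1 to compound 3.

Compound 4 `CC1=CC(=O)/C(=C(/C)Nc2ccc3c(Cl)nn(Cc4ccc(C)cc4)c3c2)C(=O)O1` is not yet measured in this assay. It arises from compound 3 by 4-methylphenyl in place of vinyl on a saturated chain carbon bound to an aromatic nitrogen, the same change that leads from compound 1 to compound 2, and the two cores differ by chloro in place of hydrogen on an aromatic carbon. The step from compound 1 to compound 2 stayed at the limit (the limit of > 100000 nM in this assay, at which 3 of the 3 values shown sit), and compound 3 sits at that limit too. On that basis compound 4 is expected to remain there; the expected step is a step that the limit leaves unreadable from compound 3 to compound 4. The estimate for compound 4 is 150000 nM, with the range 60000 nM to 400000 nM, most likely reported as a limit.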

Compound 4, half-maximal cytotoxic concentration: > 100000 nM
Compound 4 ended at the assay's limit; the forecaster's own chance of this, stated with the estimate: 85%; the middle value does not contradict the limit.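

In this assay compound 4 gives > 100000 nM, a limit and not a number. The steps to compound 4 from compound 3 and from compound 2 therefore cannot be read in size: the limit of > 100000 nM in this assay, at which 4 of the 4 values shown sit.

The compounds shown leave open at what concentration, if any, these four compounds become cytotoxic, and whether 4-methylbenzyl in place of allyl or chloro in place of hydrogen changes it.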